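An Acetyl Group in Place of Bromine on the Fused Ring

This account rests on a few compounds, and the source may have more. Where it says the series, first, only, none or still open, it means among the compounds named here.

The series rests on one shared core, carried by compound 1 `O=C1Nc2ccc(Cl)cc2/C1=C/c1cccc(OCc2cn(Cc3ccccc3)nn2)c1`, compound 2 `O=C1Nc2ccc(Br)cc2/C1=C/c1cccc(OCc2cn(Cc3ccccc3)nn2)c1` and compound 3 `O=C1Nc2ccc(F)cc2/C1=C\c1cccc(OCc2cn(Cc3ccccc3)nn2)c1`. In a functional assay on DU-145 cells (Homo sapiens) for inhibition, read by MTT assay, with a stated time of 48 h (a higher number here means a weaker inhibitor, a lower number a stronger inhibitor), compound 1 gives 24200 nM, and in the same test compound 2 gives 35100 nM; for compound 3 the entry reads "not determined" (no result reported), so no number is available for it. Going by the values given here, the single step among the measured compounds, a 1.5-fold higher number from compound 1 to compound 2 (0.16 log units; within the scatter), covers bromo in place of chloro on an aromatic carbon. Compound 2 thus holds the higher of the two numbers, with compound 1 nearest and inside the scatter, so the two cannot be ranked against each other.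

Compound 4 `CC(=O)c1ccc2c(c1)/C(=C/c1cccc(OCc3cn(Cc4ccccc4)nn3)c1)C(=O)N2` is reached from compound 2 through (acetyl in place of bromo on an aromatic carbon). Among the compounds with values here, no measured step touches an acetyl group; the only step available, a 1.5-fold higher number from compound 1 to compound 2 (0.16 log units; within the scatter), exchanges chloro for bromo and stays within the scatter, so it gives no direction for a change of this kind. With nothing to point either way, the step is expected to remain within the scatter, as a 1.2-fold lower number from compound 2 to compound 4 (0.07 log units; within the scatter), though the uncertainty is wide. Compound 4 is therefore estimated at 30000 nM in this assay, with a range from 8000 nM to 100000 nM.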

Compound 4, half-maximal inhibitory concentration: > 50000 nM
Compound 4: a limit, no number; the forecaster's own chance of this, stated with the estimate: 15%; middle value at least 1.6-fold (0.22 log units) away from the limit.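

In this assay compound 4 carries a limit of the assay and not a number: the limit of > 50000 nM in this assay, at which 1 of the 4 values shown sits. Set against compound 2, acetyl in place of bromo gives an at least 1.4-fold higher number from compound 2 to compound 4 (0.15 log units; that floor lies within the scatter), so this step alone does not separate the two groups beyond the scatter. Set against compound 1, acetyl in place of chloro gives an at least 2.0-fold higher number from compound 1 to compound 4 (0.31 log units; beyond the scatter), the first step in the series to pass the scatter, which shows what the exchange of chloro for bromo could not: this aromatic carbon of the fused system does respond to the group it carries, here towards a weaker inhibitor.

On these data alone, how far compound 4 lies past its limit stays open, so the size of the acetyl step remains unknown in both comparisons. Also open, as far as these compounds go, is whether an amine or a carboxylic acid on this aromatic carbon would give a stronger or a weaker inhibitor than the chloro of compound 1.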